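This account rests on a few compounds, and the source may have more. Where it says the series, first, only, none or still open, it means among the compounds named here.

Two compounds with the shared core of compound 1 `NCc1ccc(C(=O)Nc2ccncc2)cc1-c1cccc(C(=O)OCc2ccccc2)c1` have been measured in an assay on isolated protein for inhibition of Rho-associated protein kinase 2 (Homo sapiens), read by radiometric assay; on this read-out lower numbers stand for stronger inhibition and higher numbers for weaker inhibition. In this assay compound 1 gives 45 nM, the lowest of the two numbers, while compound 2 `NCc1ccc(C(=O)Nc2ccncc2F)cc1-c1cccc(C(=O)O)c1`, which differs in two places at once, gives 55 nM; the gap between compound 1 and compound 2 lies within the scatter, so the two values show no difference in potency that can be read as real.

The next compound, compound 3 `COC(=O)c1cccc(-c2cc(C(=O)Nc3ccncc3)ccc2CN)c1`, is compound 1 with one alteration: hydrogen in place of phenyl on a saturated chain carbon bound to an oxygen next to a carbonyl group. The benzyloxycarbonyl group of compound 1 thus becomes a methoxycarbonyl group, with the rest of the molecule untouched.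

Within the data shown here, no pair of measured compounds shows this change on its own, so the size of the step can only be guessed. Because compound 1 sits at 45 nM and the removed phenyl lies at the far end of the ester chain, compound 3 is expected to stay close to compound 1, with a step from compound 1 to compound 3 of a 1.3-fold higher number from compound 1 to compound 3 (0.12 log units; within the scatter) and no shift beyond the scatter. Compound 3 is estimated at 60 nM in this assay, with a range from 20 nM to 180 nM.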

Compound 3, half-maximal inhibitory concentration: 2.9 nM
The estimate for compound 3 lay 21-fold (1.32 log units) above the measured number; the whole stated range lies above it.
By their numbers in this assay, from the lowest: compound 3; then compounds 1 and 2 (each within the scatter of the next).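

In this assay, the ester proves to be a place where the potency responds strongly: hydrogen in place of phenyl on a saturated chain carbon bound to an oxygen next to a carbonyl group, which turns benzyloxycarbonyl into methoxycarbonyl, gives a 16-fold lower number from compound 1 to compound 3 (1.19 log units; beyond the scatter). The earlier compounds shown here could not show this, since compound 1 and compound 2 differ in two places at once, whereas this pair isolates a single change and shows that the benzyl group is not a neutral passenger on the ester. No measurement at hand accounts for the size of this step.

As far as these compounds go, with only benzyl and methyl compared on this ester, it remains open how the potency would behave with an ethyl ester, a longer chain or a primary amide in the same place. From the compounds shown here alone, compound 2 carries a carboxylic acid, but alongside a second difference, so the effect of the free acid alone on the shared core of compound 1 and compound 3 also remains open.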